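Swapping bromo for nitro at the solubility limit

The source may hold more compounds than are shown below. What is called first, only, known or untested is meant among the compounds shown, and "the series" means these compounds.

In a physicochemical assay for solubility, in phosphate buffer (on this read-out higher numbers stand for higher solubility and lower numbers for lower solubility), compound 1 (`CN(Cc1ccccc1)C(=O)C1CCCN(Cc2ccc(C(F)(F)F)cc2)C1`) gives > 100000 nM, which is a limit of the assay and not a number. Compound 2 (`CN(Cc1ccccc1)C(=O)C1CCCN(Cc2ccc(Br)cc2)C1`) gives > 100000 nM, which is also a limit and not a number. So compound 2 has no exact standing, and the evidence is simply (the limit of > 100000 nM in this assay, at which 2 of the 2 values shown sit). Going by the values given here, the one measured step is a step that the two limits leave unreadable from compound 1 to compound 2, where bromo takes the place of trifluoromethyl on an aromatic carbon. Compound 3 (`CN(Cc1ccccc1)C(=O)C1CCCN(Cc2ccc([N+](=O)[O-])cc2)C1`) brings a new change, nitro in place of bromo on an aromatic carbon. The step to compound 2 offers no readable size to carry over, so no step beyond the scatter is expected in this assay, and no direction can be named. The expected step is a step that the limit leaves unreadable from compound 2 to compound 3. For compound 3, the estimated value is 120000 nM, with an expected range from 50000 nM to 250000 nM.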

Compound 3, solubility: > 100000 nM
Compound 3 ended at the assay's limit; the forecaster's own chance of this, stated with the estimate: 80%; the middle value is on the limit's open side.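

In this assay compound 3 gives > 100000 nM, which is a limit of the assay and not a number. Going by these compounds alone, compound 1, compound 2 and compound 3 all sit at this same limit, so no step among them can be read. The compounds shown leave open whether trifluoromethyl, bromo and nitro differ at all in this assay.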